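One group swapped on a shared core

A few compounds are considered here, and "the series" means these few. Any claim that something is new, unique, unknown or untested is made for them only; others in the source may bear on it.

Values in an ADME assay on Huh-5-2 cells (Homo sapiens) for cytotoxicity, with a stated time of 3 days; on this read-out higher numbers stand for lower toxicity in this test and lower numbers for higher toxicity in this test:
Compound 1 `CCOC(=O)c1csc([C@H]2[C@@H](COC)C[C@@](CC(C)C)(C(=O)O)N2C(=O)c2ccc(C(C)(C)C)c(OC)c2)n1`: 200000 nM
Compound 2 `COC[C@H]1C[C@@](CC(C)C)(C(=O)O)N(C(=O)c2ccc(C(C)(C)C)c(OC)c2)[C@H]1[C@H]1COC(C)(C)O1`: > 120000 nM
Compound 3 `COC[C@H]1C[C@@](CC(C)C)(C(=O)O)N(C(=O)c2ccc(C(C)(C)C)c(OC)c2)[C@H]1C(N)=O`: > 120000 nM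
Compound 4 `COC[C@H]1C[C@@](CC(C)C)(C(=O)O)N(C(=O)c2ccc(C(C)(C)C)c(OC)c2)[C@H]1COC(C)=O`: not yet measured

Compound 2 stands at > 120000 nM, which is a limit of the assay and not a number. Compound 3 stands at > 120000 nM, which is also a limit. Together they make up (the limit of > 120000 nM in this assay, at which 2 of the 3 values shown sit). Only compound 1 gives an actual number, 200000 nM.

The move to compound 4 changes one group, on a saturated ring carbon next to the ring nitrogen: acetoxymethyl in place of 2,2-dimethyl-1,3-dioxolan-4-yl (acetoxymethyl in place of 2,2-dimethyl-1,3-dioxolan-4-yl on a saturated ring carbon). The rest of the molecule stays the same.

Three measured steps change a group on this same carbon: a step that the limit leaves unreadable from compound 1 to compound 2, a step that the limit leaves unreadable from compound 1 to compound 3 and a step that the two limits leave unreadable from compound 2 to compound 3. None of them has a size that can be read. Still, none of the three groups tried there, 4-(ethoxycarbonyl)-1,3-thiazol-2-yl, 2,2-dimethyl-1,3-dioxolan-4-yl and carbamoyl, brought a value under that limit. For compound 4, therefore, no step beyond the usual scatter is expected in this assay, in either direction. The expected change is a step that the limit leaves unreadable from compound 2 to compound 4. Compound 4 is estimated at 150000 nM, with an expected range of 100000 nM to 250000 nM, and the assay may well report only a limit again.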

Compound 4, half-maximal cytotoxic concentration: > 120000 nM
Compound 4: a limit, no number (the forecaster's own chance of this, stated with the estimate: 75%); the middle value does not contradict the limit.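

In this assay compound 4 gives > 120000 nM, which is a limit and not a number. No step from compound 1, compound 2 or compound 3 to compound 4 can be read, because the values mostly stop at a limit: the limit of > 120000 nM in this assay, at which 3 of the 4 values shown sit.

The compounds shown leave open how far compound 2, compound 3 and compound 4 truly differ from one another or from compound 1.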